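Moving from a fluoro to a methylpiperazine on compound 3

A few compounds are considered here, and "the series" means these few. Any claim that something is new, unique, unknown or untested is made for them only; others in the source may bear on it.

Of the compounds shown here, three have been measured in an assay on a protein complex for inhibition of CDK8/Cyclin C (Homo sapiens), with a stated time of 1 h, tested at 10 uM; on this read-out lower numbers stand for less inhibition and higher numbers for more inhibition at the one concentration tested (going by the name of the read-out). Compound 1 `CNC(=O)/C=C/c1ccncc1-c1ccc2cccnc2c1` gives 82%, and compound 2 `O=C(/C=C/c1ccncc1-c1ccc2[nH]ccc2c1)N1CCOCC1` gives 97%. Compound 3 `NC(=O)/C=C/c1ccncc1Nc1ccc(F)cc1` gives 70% in this assay, the lowest of the three numbers: compound 1 sits higher and compound 2 higher still, and both of those gaps lie beyond the usual scatter of repeated measurements.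

Compound 4 `CN1CCN(c2ccc(Nc3cnccc3/C=C/C(N)=O)cc2)CC1` has not yet been measured. It differs from compound 3 in one place: 4-methylpiperazin-1-yl in place of fluoro on an aromatic carbon. The place is an aromatic carbon of a six-membered aromatic ring of carbon only, para to a large group. Within the data shown here, no measured pair in this set shows exactly this kind of change, so there is no directly comparable step to lean on.

Given that compound 3 already reaches 70% in this assay, a small rise is expected for compound 4, of a size that may well stay within the scatter rather than beyond it. The step from compound 3 to compound 4 is estimated at a number 8 percentage points higher from compound 3 to compound 4 (within the scatter). For compound 4 the expected reading in this assay is 78%, with a likely range from 60% to 92%.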

Compound 4, a percentage reported as inhibition, at one concentration (the size of the read-out at that concentration, not a potency): 75%
For compound 4 the middle estimate is 3 percentage points above the measured one, within the range that was stated.
By their numbers in this assay, from the lowest: compounds 3, 4 and 1 (each within the scatter of the next, the first and the last beyond it); then compound 2.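

In this assay, replacing the single fluoro with 4-methylpiperazin-1-yl, which brings 7 heavy atoms, a six-membered non-aromatic ring and 2 hydrogen-bond acceptors, gives a number 5 percentage points higher from compound 3 to compound 4 (within the scatter), so the two readings cannot be told apart. Among these compounds, this is the first view of this position, an aromatic carbon para to a large group, and it shows that a much larger group can sit there with no loss of inhibition beyond the scatter at the one concentration tested, although such a reading is not a measure of potency. Nothing available explains why the reading holds up across so large a change in the group.

The compounds shown leave open whether the ring or its methyl matters for this reading, which a piperazine without the methyl or a smaller dimethylamino group at the same carbon could help to separate. They also leave open how a group of a different kind, such as a carboxylic acid, would read there, and whether the same replacement would behave alike on another core.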